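The compounds below may be only part of what the source reports. "The series", "measured", "known", "first", "only" and "open" are said of these compounds alone.

compound 1 `Cn1nccc1-c1ccccc1NCC1=NCCN1`: 0%
compound 2 `Cc1nc(-c2ccccc2NCC2=NCCN2)n(C)n1`: 0%
compound 3 `c1ccc(-c2nc[nH]n2)c(NCC2=NCCN2)c1`: 100%

In a functional assay with Alpha-1B adrenergic receptor (Homo sapiens) as the target, read by calcium flux (a higher number here means a larger maximal response, a lower number a smaller maximal response), compound 1 gives 0%, which at the digits shown is the same number as compound 2 with 0%, so these two together stand lowest of the three; compound 3, by contrast, gives 100%. Within the data shown here, only one measured pair differs in a single place: a number 100 percentage points higher from compound 1 to compound 3 (beyond the scatter), a large jump that came from exchanging the whole five-membered heteroaryl group on the shared core.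

Compound 4 `CCn1nccc1-c1ccccc1NCC1=NCCN1` is reached from compound 1 by a smaller change: methyl in place of hydrogen on a saturated chain carbon bound to an aromatic nitrogen. Among the measured compounds shown here, no measured step touches this part of the molecule, so nothing directly tells how it should behave. What can be said is that the large jump occurred only when the heteroaryl group itself was replaced, and that compound 2, which also carries a methyl on a ring nitrogen, sits at the same zero as compound 1. Lengthening the chain on that nitrogen is therefore expected to give no step beyond the scatter, with the step of a number 5 percentage points higher from compound 1 to compound 4 (within the scatter) estimated. Compound 4 is expected to give 5%, within 0% to 25%.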

Compound 4, largest response reached (reported as maximal response), in percent of the reference or control that the assay uses: 0%
Estimate against measurement, compound 4: 5 percentage points above, within the range that was stated.
By their numbers in this assay, from the lowest: compounds 1, 2 and 4 (each within the scatter of the next); then compound 3.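

In this assay, the first change shown at this position, methyl to ethyl on the ring nitrogen, gives no change at the digits printed from compound 1 to compound 4 (within the scatter). Adding this one carbon to the chain therefore does not bring back any of the response seen with the triazolyl group of compound 3, so lengthening the chain by this amount does not by itself separate compound 4 from compound 1. The reading has a clear limitation, since compound 1 already gives 0% and any harm from the added carbon would not show up as a lower number, and nothing available accounts for the unchanged response.

Going by these compounds, the large step of a number 100 percentage points higher from compound 1 to compound 3 (beyond the scatter) still replaces the whole heteroaryl group, so it remains open whether the response depends on the ring atoms as a whole or on the absence of an alkyl group on the ring nitrogen. A 1H-pyrazol-5-yl group, with hydrogen on that nitrogen, would bear directly on this question, while a longer chain such as propyl or a 2-hydroxyethyl group would test the position further.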